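The source may report more compounds than this note shows. Statements on the series, on what has been measured and on what is new or still open speak of the compounds shown alone.

Of the compounds shown here, two have been measured in an assay (Canis lupus familiaris) for binding affinity to platelet-activating factor receptor (Homo sapiens), read by radioligand binding; on this read-out lower numbers stand for stronger inhibition and higher numbers for weaker inhibition. Compound 1, with the structure `COc1ccc(-c2ccc(C(=O)NCCCCc3cccnc3)cc2[N+](=O)[O-])cc1OC`, gives 200 nM in this assay. Compound 2, with the structure `COc1cccc(-c2ccc(C(=O)NCCCCc3cccnc3)cc2)c1`, gives 280 nM in this assay. These two numbers lie within the usual scatter of repeated measurements of each other, so they are best read as equivalent; compound 2 shares the same core as compound 1 but lacks the second methoxy group and the nitro group.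

Compound 3, with the structure `COc1ccc(-c2ccc(C(=O)NCCCCc3cccnc3)cc2)cc1OC`, has not been measured in this assay. It is obtained from compound 2 by the change (methoxy in place of hydrogen on an aromatic carbon), so that compound 3 carries the same two methoxy groups as compound 1 without its nitro group. Among the compounds with values here, nothing among the measured pairs shows a step for this change on its own, and the two measured numbers sit close together. The step of a 1.3-fold lower number from compound 2 to compound 3 (0.10 log units; within the scatter) is therefore expected to stay within the scatter. On that basis compound 3 is estimated at 220 nM in this assay, with a range from 80 nM to 600 nM.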

Compound 3, half-maximal inhibitory concentration: 400 nM
Beside the measured number, compound 3's estimate is 1.8-fold (0.26 log units) below it; the measured number falls inside the stated range.
By their numbers in this assay, from the lowest: compounds 1, 2 and 3 (each within the scatter of the next).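

Within the data shown here, compound 3 gives the first comparisons that differ in one place, and in this assay neither can be told apart from repeat-measurement scatter. Placing a methoxy group ortho to the existing methoxy group gives a 1.4-fold higher number from compound 2 to compound 3 (0.15 log units; within the scatter), and placing hydrogen where the nitro group stood gives a 2.0-fold higher number from compound 1 to compound 3 (0.30 log units; within the scatter). Each group, taken on its own, therefore leaves the reading within the scatter, and the three compounds are best read as equivalent; nothing available offers an explanation for this result.

The compounds shown carry only hydrogen, methoxy or nitro at these places, so it stays open whether a different group there, such as an amine or a carboxylic acid, would give a step beyond the scatter. It is also open whether the methoxy step would read the same on a core that keeps the nitro group, since the compounds shown hold no partner for compound 1 that lacks only the second methoxy group.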